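The source may hold more compounds than are shown below. What is called first, only, known or untested is meant among the compounds shown, and "the series" means these compounds.

Within the data shown here, compound 3 `CCCCOc1ccc(C(CC)NC(=O)Oc2ccc(F)cc2F)cc1` gives 21 nM in an assay on H4 cells for inhibition of Fatty-acid amide hydrolase 1 (Homo sapiens) (on this read-out lower numbers stand for stronger inhibition and higher numbers for weaker inhibition), the lowest number of the three measured so far. Compound 2 `CCCCOc1ccc(NC(=O)Oc2ccccc2F)cc1` gives 340 nM, and compound 1 `O=C(Nc1ccc(Oc2ccccc2)cc1)Oc1ccccc1F` gives 1300 nM. Compound 4 `CCCCOc1ccc(C(CC)NC(=O)Oc2ccccc2)cc1` differs from compound 3 in one place: phenyl in place of 2,4-difluorophenyl on an oxygen next to a carbonyl group. Among the measured compounds shown here, the only one-place step measured, a 3.8-fold lower number from compound 1 to compound 2 (0.58 log units; beyond the scatter), concerns the group on an oxygen on the other aromatic ring and does not touch the phenyl on the oxygen next to the carbonyl group, so no measured step bears directly on this change. Going by these compounds, compounds 1 and 2 carry a different fluorinated phenyl on that oxygen than compound 3, but compound 3 also differs from them elsewhere, so the share of the fluorines is unknown. A modest rise, possibly within the scatter, is expected: a 1.9-fold higher number from compound 3 to compound 4 (0.28 log units; within the scatter). Compound 4 is estimated at 40 nM, within 15 nM to 120 nM.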

Compound 4, half-maximal inhibitory concentration: 12 nM
Beside the measured number, compound 4's estimate is 3.3-fold (0.52 log units) above it, and the stated range ends above it.
By their numbers in this assay, from the lowest: compounds 4 and 3 (each within the scatter of the next); then compound 2; then compound 1.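

In this assay, phenyl in place of 2,4-difluorophenyl on an oxygen next to a carbonyl group gives a 1.8-fold lower number from compound 3 to compound 4 (0.24 log units; within the scatter), so at this place the pair shows no dependence on the two fluorines beyond the scatter. Among these compounds, compound 4 thus holds a low number with an unsubstituted phenyl, which the earlier compounds could not show. Nothing at hand explains this outcome.
Going by these compounds, whether a chlorine, a methoxy group or an amine on this phenyl would keep the number stays open. Also open, on these data alone, is whether the fluorine in compound 1 and compound 2 matters in their setting.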